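Cytotoxicity notes: from compound 3 to compound 4

The source may report more compounds than this note shows. Statements on the series, on what has been measured and on what is new or still open speak of the compounds shown alone.

Compound 1 `Cc1ccccc1-c1nn(-c2ccc(F)cc2F)cc1CNCCCCO`: in an ADME assay on Huh-7 cells (Homo sapiens) for cytotoxicity (on this read-out higher numbers stand for lower toxicity in this test and lower numbers for higher toxicity in this test), compound 1 gives > 20000 nM, a limit of the assay.
Compound 2 `Cc1ccccc1-c1nn(-c2ccc(F)cc2F)cc1CNCCCN1CCN(C)CC1`: in this assay compound 2 gives > 20000 nM, again a limit.
Compound 3 `Cc1ccccc1-c1nn(-c2ccc(F)cc2F)cc1CNC1CCN(S(C)(=O)=O)CC1`: in this assay compound 3 gives > 20000 nM, also a limit.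

Compound 3 therefore stands at the ceiling of the numbers shown, and the limit of > 20000 nM in this assay, at which 3 of the 3 values shown sit, holds for every measured member. Among the measured compounds shown here, the steps a step that the two limits leave unreadable from compound 1 to compound 2, a step that the two limits leave unreadable from compound 1 to compound 3 and a step that the two limits leave unreadable from compound 2 to compound 3 are all unreadable, so no measured step gives a size.

Compound 4 `Cc1ccccc1-c1nn(-c2ccc(F)cc2F)cc1CNCc1ccncc1` differs from compound 3 by (pyridin-4-yl)methyl in place of 1-(methylsulfonyl)piperidin-4-yl on an amine nitrogen. With three unreadable steps, no readable step in this assay is expected beyond the scatter; the step that the limit leaves unreadable from compound 3 to compound 4 is an estimate only. Compound 4 is expected at 30000 nM, between 8000 nM and 120000 nM, most probably reported as a limit.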

Compound 4, half-maximal cytotoxic concentration: > 20000 nM
Compound 4 ended at the assay's limit; the forecaster's own chance of this, stated with the estimate: 80%; the middle value does not contradict the limit.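

In this assay compound 4 gives > 20000 nM, a limit of the assay. Its steps from compound 1, compound 2 and compound 3 cannot be read. The compounds shown leave open whether the amine nitrogen substituent changes cytotoxicity at all, with every member at the same limit: the limit of > 20000 nM in this assay, at which 4 of the 4 values shown sit.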